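Swapping a methoxyphenyl for a halogenated phenyl on the piperazine

A few compounds are considered here, and "the series" means these few. Any claim that something is new, unique, unknown or untested is made for them only; others in the source may bear on it.

Measured so far:
compound 1, `Nc1scc(CN2CCN(c3ccc(Cl)cc3Cl)CC2)c1C(=O)c1ccc(Cl)cc1`, in a functional assay on CHO cells with adenosine receptor A1 (Homo sapiens) as the target, read by cAMP accumulation and immunoassay, with a stated time of 6 min, tested at 10 uM (a lower number here means a stronger effect, a higher number a weaker effect of the compound at the concentration tested), gives -74%
compound 2, `COc1ccc(N2CCN(Cc3csc(N)c3C(=O)c3ccc(Cl)cc3)CC2)cc1`, in this assay gives -52%
compound 3, `Nc1scc(CN2CCN(c3ccc(F)c(F)c3)CC2)c1C(=O)c1ccc(Cl)cc1`, in this assay gives -87%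

All three share one core and differ only in the aromatic group on an amine nitrogen in a ring. Compound 2 stands highest of the three, so its effect is the weakest: compound 1 is a number 22 percentage points higher from compound 1 to compound 2 (beyond the scatter) away, and compound 3 is further still, a number 35 percentage points lower from compound 2 to compound 3 (beyond the scatter). Compound 4, `Nc1scc(CN2CCN(c3ccc(F)c(Cl)c3)CC2)c1C(=O)c1ccc(Cl)cc1`, has not yet been measured; it differs from compound 2 by 3-chloro-4-fluorophenyl in place of 4-methoxyphenyl on an amine nitrogen in a ring. Among the measured compounds shown here, two measured steps bear on this change. Replacing the 4-methoxyphenyl by a halogenated phenyl gave a number 35 percentage points lower from compound 2 to compound 3 (beyond the scatter), a large drop, and moving between two halogenated phenyls gave only a number 13 percentage points lower from compound 1 to compound 3 (beyond the scatter). A large step downward is therefore expected in this assay, about a number 30 percentage points lower from compound 2 to compound 4 (beyond the scatter). Compound 4 is estimated at -82%, within -95% to -65%.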

Compound 4, a percentage reported as activity, at one concentration (the size of the read-out at that concentration, not a potency): -78%
Compound 4: middle estimate off by 4 percentage points, on the low side, and the stated range covers the measured number.
By their numbers in this assay, from the lowest: compounds 3, 4 and 1 (each within the scatter of the next, the first and the last beyond it); then compound 2.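

In this assay the third halogenated phenyl also stands clear of the 4-methoxyphenyl of compound 2 (a number 26 percentage points lower from compound 2 to compound 4 (beyond the scatter)), so all three halogenated compounds shown now differ from it beyond the scatter. Among those three, the exact halogen pattern matters less: chloro in place of fluoro on an aromatic carbon stays within the scatter (a number 9 percentage points higher from compound 3 to compound 4 (within the scatter)), and so does the change from 2,4-dichlorophenyl to 3-chloro-4-fluorophenyl (a number 4 percentage points lower from compound 1 to compound 4 (within the scatter)). Nothing available here explains why the halogenated phenyls and the 4-methoxyphenyl read differently.

The compounds shown leave open how a phenyl with no substituent, or one carrying a nitrile or a trifluoromethyl, would read, and so whether halogens are needed at all. On these data alone, these are also readings at a single concentration, so potency remains open.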